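The source may report more compounds than this note shows. Statements on the series, on what has been measured and on what is new or still open speak of the compounds shown alone.

Compound 1 `COc1ccc(/C=N/NC(=O)Nc2ccc(Oc3ccnc4cc(OCCCN5CCCCC5)c(OC)cc34)c(F)c2)cc1` is one of three measured compounds sharing a common core; in a functional assay on MDA-MB-231 cells (Homo sapiens) for cytotoxicity, read by MTT assay, with a stated time of 72 h (on this read-out higher numbers stand for weaker inhibition and lower numbers for stronger inhibition), compound 1 gives 840 nM. Its two neighbours differ at the far end of the molecule: compound 2 `COc1cc2c(Oc3ccc(NC(=O)N/N=C/c4ccc(OC(F)(F)F)cc4)cc3F)ccnc2cc1OCCCN1CCCCC1` gives 820 nM, with a 1.0-fold lower number from compound 1 to compound 2 (0.01 log units; within the scatter), and compound 3 `COc1cc2c(Oc3ccc(NC(=O)N/N=C/c4cc5ccccc5[nH]4)cc3F)ccnc2cc1OCCCN1CCCCC1` gives 980 nM, with a 1.2-fold higher number from compound 1 to compound 3 (0.07 log units; within the scatter). All three numbers therefore lie within the scatter of one another. Compound 4 `COc1ccc(/C=N/NC(=O)Nc2ccc(Oc3ccnc4cc(OCCCN5CCC(C)CC5)c(OC)cc34)c(F)c2)cc1` changes a different part, the saturated ring at the end of the chain: methyl in place of hydrogen on a saturated ring carbon. Among the measured compounds shown here, no measured step touches that ring, so nothing directly bears on this change; the only guidance is that the measured steps all stayed within the scatter. The expected step is a 1.1-fold higher number from compound 1 to compound 4 (0.03 log units; within the scatter), so compound 4 is estimated at 900 nM, within 450 nM to 1800 nM.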

Compound 4, half-maximal inhibitory concentration: 1000 nM
Compound 4: middle estimate off by 1.1-fold (0.05 log units), on the low side, and the stated range covers the measured number.
By their numbers in this assay, from the lowest: compounds 2, 1, 3 and 4 (each within the scatter of the next).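

In this assay, among the compounds shown here, the change from piperidin-1-yl to 4-methylpiperidin-1-yl gives a 1.2-fold higher number from compound 1 to compound 4 (0.08 log units; within the scatter) for the first measured step on the saturated ring. So one added methyl, three ring bonds from the ring nitrogen, leaves the number within the scatter, just as the changes at the far end of the molecule did. No evidence bearing on this result is available.

One small group says little about this position. A carboxylic acid or a phenyl ring at the same ring carbon could behave differently, and so could a morpholine in place of the whole piperidine.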